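Pyridin-2-yl for Pyridin-3-yl: Compound 3 to Compound 4

A few compounds are considered here, and "the series" means these few. Any claim that something is new, unique, unknown or untested is made for them only; others in the source may bear on it.

Compound 3 `N#CN/C(=N\C1CCCCC1)Nc1cccnc1` gives 20 mg/kg in a functional assay on the whole organism (blood, strain Wistar-Okamoto) with Rattus norvegicus as the target, with a stated time of 5 days; a higher number here means that more compound is needed for the effect, a lower number that less compound is needed. Compound 2 `N#CN/C(=N\C1CCCC1)Nc1cccnc1` gives 20 mg/kg, and the step was no change at the digits printed from compound 2 to compound 3 (within the scatter). Compound 1 `CC(C)/N=C(\NC#N)Nc1cccnc1` gives 2.5 mg/kg; the steps were an 8.0-fold higher number from compound 1 to compound 2 (0.90 log units; beyond the scatter) and an 8.0-fold higher number from compound 1 to compound 3 (0.90 log units; beyond the scatter). Compound 3 therefore sits level with compound 2, and the two share the highest numbers of the three.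

Compound 4 `N#CN/C(=N\C1CCCCC1)Nc1ccccn1` differs from compound 3 by one change: pyridin-2-yl in place of pyridin-3-yl on an amine nitrogen. Every measured step alters the group on the double-bonded nitrogen, so none bears directly on this change. The expected step is no change at the digits printed from compound 3 to compound 4 (within the scatter), with little reason to foresee a move beyond the scatter. For compound 4 the estimated value is 20 mg/kg, ranging from 6 mg/kg to 60 mg/kg.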

Compound 4, minimum effective dose: > 35 mg/kg
Compound 4: a limit, no number (the forecaster's own chance of this, stated with the estimate: 10%); middle value at least 1.7-fold (0.24 log units) away from the limit.
By their numbers in this assay, from the lowest: compound 1; then compounds 2 and 3 (each within the scatter of the next). At a limit, above all of these: compound 4.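

The earlier compounds shown here differ only in the group on the double-bonded nitrogen, whereas this change on the amine nitrogen gives an at least 1.7-fold higher number from compound 3 to compound 4 (0.24 log units; that floor lies within the scatter). Compound 4 stands at a limit, not a number: the limit of > 35 mg/kg in this assay, at which 1 of the 4 values shown sits.

The floor of that step does not separate compound 4 from compound 3, so this rearrangement of the same atoms shows no gain, but no proven loss either. Open, on these data alone, is how far compound 4 truly lies from compound 3, and how pyridin-2-yl would read with the isopropyl group of compound 1. Also open, as far as these compounds go, is what a plain phenyl or a pyridin-4-yl group would do on the amine nitrogen.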